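Swapping Bromo for Nitro on a Weak Growth Inhibitor

The compounds below may be only part of what the source reports. "The series", "measured", "known", "first", "only" and "open" are said of these compounds alone.

Measured compounds:
compound 1 `N#CCC1=NN=C(c2ccc([N+](=O)[O-])cc2)C(CC(=O)c2ccc(Br)cc2)O1` 16500 nM
compound 2 `N#CCC1=NN=C(c2ccc(Br)cc2)C(CC(=O)c2ccc([N+](=O)[O-])cc2)O1` 18500 nM

In a functional assay on SF-268 cells (Homo sapiens) for inhibition, read by sulforhodamine B assay, with a stated time of 48 h (a higher number here means a weaker inhibitor of growth, a lower number a stronger inhibitor of growth), compound 2 gives 18500 nM, and compound 1 gives 16500 nM; the two numbers lie within the usual scatter of each other, so compound 2 stands alongside compound 1 rather than apart from it. Compound 3 `N#CCC1=NN=C(c2ccc([N+](=O)[O-])cc2)C(CC(=O)c2ccc([N+](=O)[O-])cc2)O1` is not yet measured. It differs from compound 2 in one place: nitro in place of bromo on an aromatic carbon. Since compound 1 and compound 2 already carry both groups in exchanged positions without a difference beyond the scatter, the expected step of a 1.0-fold lower number from compound 2 to compound 3 (0.01 log units; within the scatter) is none beyond the scatter. Compound 3 is therefore estimated at 18000 nM, with a range from 8000 nM to 40000 nM.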

Compound 3, concentration for 50% growth inhibition: 2000 nM
For compound 3 the middle estimate is 9.0-fold (0.95 log units) above the measured one, and the stated range ends above it.
By their numbers in this assay, from the lowest: compound 3; then compounds 1 and 2 (each within the scatter of the next).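

Nitro in place of bromo gives a 9.3-fold lower number from compound 2 to compound 3 (0.97 log units; beyond the scatter), and the same change on the other aromatic ring gives an 8.3-fold lower number from compound 1 to compound 3 (0.92 log units; beyond the scatter). Moving the two groups between the rings separated nothing, whereas having nitro on both rings sets compound 3 apart from compound 1 and compound 2. Nothing measured here explains this gain. Still open, as far as these compounds go, is whether another group in the same place, such as an amine or a carboxylic acid, would give a similar number. A compound with bromo on both rings would also be needed to show how the two rings contribute.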